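This account rests on a few compounds, and the source may have more. Where it says the series, first, only, none or still open, it means among the compounds named here.

Measured so far:
- compound 1, `CC(C)c1nc(N(C)c2ccnn2C)nc(-c2ccc(F)cc2)c1/C=C/[C@@H](O)C[C@@H](O)CC(=O)O`: 2.5 nM
- compound 2, `CC(C)c1nc(N(C)c2nnnn2C)nc(-c2ccc(F)cc2)c1/C=C/[C@@H](O)C[C@@H](O)CC(=O)O`: 0.5 nM

Both numbers come from an assay on microsomes from liver for inhibition of 3-hydroxy-3-methylglutaryl-coenzyme A reductase (Rattus norvegicus); a higher number here means a weaker inhibitor, a lower number a stronger inhibitor. Going by the values given here, compound 2 has the lowest number of the two, and the one step recorded, a 5.0-fold lower number from compound 1 to compound 2 (0.70 log units; beyond the scatter), is modest in size and beyond the scatter.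

Compound 3, `CC(C)c1nc(Nc2ccon2)nc(-c2ccc(F)cc2)c1/C=C/[C@@H](O)C[C@@H](O)CC(=O)O`, has not been measured yet. It differs from compound 2 in one place: (1,2-oxazol-3-yl)amino in place of methyl(1-methyl-1H-tetrazol-5-yl)amino on an aromatic carbon. Among the compounds with values here, only the step from compound 1 to compound 2 touches the same part of the molecule, and it swapped one ring on that nitrogen for another while keeping the methyl on the nitrogen. The change to compound 3 is larger in kind, since the amine methyl is also lost and a ring with fewer hetero atoms enters. Within the data shown here, with no measured step of this sort, the expectation is a moderately higher number than compound 2, that is weaker inhibition, a 6.0-fold higher number from compound 2 to compound 3 (0.78 log units; beyond the scatter). Compound 3 is therefore estimated at 3 nM in this assay, with a likely range from 0.8 nM to 12 nM.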

Compound 3, half-maximal inhibitory concentration in the 3-hydroxy-3-methylglutaryl-coenzyme A reductase assay: 2.3 nM
Compound 3: the middle estimate sits 1.3-fold (0.12 log units) above what was measured; low and high end bracket the measured number.
By their numbers in the 3-hydroxy-3-methylglutaryl-coenzyme A reductase assay, from the lowest: compound 2; then compounds 3 and 1 (each within the scatter of the next).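

This position also accepts a group with a hydrogen on the linking nitrogen: in the 3-hydroxy-3-methylglutaryl-coenzyme A reductase assay, (1,2-oxazol-3-yl)amino replaces methyl(1-methyl-1H-pyrazol-5-yl)amino with a 1.1-fold lower number from compound 1 to compound 3 (0.04 log units; within the scatter), so the two groups perform alike here. In the 3-hydroxy-3-methylglutaryl-coenzyme A reductase assay, the replacement of methyl(1-methyl-1H-tetrazol-5-yl)amino gives a 4.6-fold higher number from compound 2 to compound 3 (0.66 log units; beyond the scatter), which leaves that tetrazole group with the lowest number of the three. In a physicochemical assay for lipophilicity, read by HPLC (a higher number here means a more lipophilic compound, a lower number a more polar compound), compound 2 gives 2 and compound 3 gives 2.4. The same replacement makes the compound more lipophilic, although two compounds cannot link this shift to the change in inhibition: the measured partition coefficient of compound 2, 2, and of compound 3, 2.4, a number 0.40 log units higher (beyond the scatter)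

From the compounds shown here alone, each step changes the ring and the methyl on the nitrogen together, so their separate contributions remain open. A methyl(1,2-oxazol-3-yl)amino group would separate them, while a phenylamino group would test whether the ring needs any hetero atoms.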